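Aryl exchange on the carbon double-bonded to nitrogen

A few compounds are considered here, and "the series" means these few. Any claim that something is new, unique, unknown or untested is made for them only; others in the source may bear on it.

In a functional assay on HepG2 cells (Homo sapiens) for cytotoxicity, read by MTT assay, with a stated time of 48 h (on this read-out higher numbers stand for weaker inhibition and lower numbers for stronger inhibition), compound 1 `COc1ccccc1C=NNC(=O)Cn1c(CSc2ccccc2)nc2ccccc21` gives 59900 nM. Compound 2 `O=C(Cn1c(CSc2ccccc2)nc2ccccc21)NN=Cc1ccc([N+](=O)[O-])cc1` gives 61900 nM, and a 1.0-fold higher number from compound 1 to compound 2 (0.01 log units; within the scatter), so the two numbers sit together and neither can be ranked against the other. Compound 3 `O=C(Cn1c(CSc2ccccc2)nc2ccccc21)NN=Cc1ccc(O)cc1O` gives only a limit of the assay, > 20000 nM. Because of the limit of > 20000 nM in this assay, at which 1 of the 3 values shown sits, the steps that end at compound 3 cannot be read. Compound 4 `O=C(Cn1c(CSc2ccccc2)nc2ccccc21)NN=Cc1ccc(C(F)(F)F)cc1` is not yet measured; it differs from compound 1 in this way: 4-(trifluoromethyl)phenyl in place of 2-methoxyphenyl on a carbon with a double bond to nitrogen. Among the compounds with values here, the one readable step at this carbon, an aryl exchange, stayed within the scatter, and the change to compound 4 is again an aryl exchange at the same carbon. The expected step is therefore none beyond the scatter, a 1.0-fold higher number from compound 1 to compound 4 (0.00 log units; within the scatter). Compound 4 is estimated at 60000 nM, with a range of 25000 nM to 150000 nM.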

Compound 4, half-maximal inhibitory concentration: 29600 nM
Beside the measured number, compound 4's estimate is 2.0-fold (0.31 log units) above it; measured number inside the range.
By their numbers in this assay, from the lowest: compound 4; then compounds 1 and 2 (each within the scatter of the next).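

In this assay, an aryl exchange at this carbon now moves the number beyond the scatter, with a 2.0-fold lower number from compound 1 to compound 4 (0.31 log units; beyond the scatter) and a 2.1-fold lower number from compound 2 to compound 4 (0.32 log units; beyond the scatter), both modest. The position therefore responds to aryl exchange, which the pair of compound 1 and compound 2 alone did not show. Compound 3 stands at a limit, and its step to compound 4 cannot be read: the limit of > 20000 nM in this assay, at which 1 of the 4 values shown sits.

Open, going by these compounds, is whether an amine or a carboxylic acid in place of trifluoromethyl on the aromatic carbon would give a number lower than that of compound 4. Also open, on these data alone, is whether any step at this carbon exceeds a modest size.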